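Aryl swap on a triazole-bearing lactone scaffold

The source may report more compounds than this note shows. Statements on the series, on what has been measured and on what is new or still open speak of the compounds shown alone.

Measured compounds:
Compound 1, `CCCCCc1ccc(-c2cn(C[C@H](O)[C@H]3OC(=O)C(OCc4ccccc4)=C3OCc3ccccc3)nn2)cc1`: 8390 nM
Compound 2, `Cc1ccc(S(=O)(=O)NCc2cn(C[C@H](O)[C@H]3OC(=O)C(OCc4ccccc4)=C3OCc3ccccc3)nn2)cc1`: 14400 nM

Compound 2, `Cc1ccc(S(=O)(=O)NCc2cn(C[C@H](O)[C@H]3OC(=O)C(OCc4ccccc4)=C3OCc3ccccc3)nn2)cc1`, gives 14400 nM in a functional assay on HeLa cells (Homo sapiens) for antiproliferative activity, read by MTT assay, with a stated time of 72 h (on this read-out lower numbers stand for stronger inhibition and higher numbers for weaker inhibition), and so holds the highest of the two numbers found so far. Its nearest neighbour is compound 1, `CCCCCc1ccc(-c2cn(C[C@H](O)[C@H]3OC(=O)C(OCc4ccccc4)=C3OCc3ccccc3)nn2)cc1`, which gives 8390 nM in this assay; the step of a 1.7-fold higher number from compound 1 to compound 2 (0.23 log units; within the scatter) lies within the scatter, so the two cannot be told apart.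

Compound 3, `COc1ccc(-c2cn(C[C@H](O)[C@H]3OC(=O)C(OCc4ccccc4)=C3OCc3ccccc3)nn2)cc1`, has not yet been measured. It differs from compound 2 in one place: 4-methoxyphenyl in place of (((4-methylphenyl)sulfonyl)amino)methyl on an aromatic carbon. Within the data shown here, the only step that bears on this change is the one between compound 1 and compound 2, where a direct aryl substituent and a sulfonamide-linked substituent gave numbers within the scatter of each other. Compound 3 returns to a directly attached aryl group, as in compound 1, so no change beyond the scatter is expected in this assay, with the expected step of a 1.4-fold lower number from compound 2 to compound 3 (0.16 log units; within the scatter). The estimate for compound 3 is 10000 nM, with a range from 3000 nM to 30000 nM.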

Compound 3, half-maximal inhibitory concentration: 16400 nM
Beside the measured number, compound 3's estimate is 1.6-fold (0.21 log units) below it; the range from low to high includes it.
By their numbers in this assay, from the lowest: compounds 1, 2 and 3 (each within the scatter of the next).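

In this assay, replacing (((4-methylphenyl)sulfonyl)amino)methyl with 4-methoxyphenyl on the aromatic carbon of the triazole gives a 1.1-fold higher number from compound 2 to compound 3 (0.06 log units; within the scatter), so a group with a hydrogen-bond donor and a sulfonyl link and a smaller, directly attached aryl group with no donor cannot be told apart here. The outer end of the directly attached aryl group adds a second comparison: methoxy in place of pentyl gives a 2.0-fold higher number from compound 1 to compound 3 (0.29 log units; within the scatter), so even a short ether and a five-carbon chain on that ring leave the numbers within the usual scatter, and all three compounds form one group with no order among them. Nothing available accounts for this flat result, and the data give no reason for it.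

These three compounds do not show whether any group at this place can move the number beyond the scatter. An amine or a carboxylic acid in place of the methoxy, or a chain longer than pentyl, would test that, as would a triazole carrying only a small alkyl group such as methyl instead of an aryl-containing substituent.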